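Swapping Methyl for Amino on the Shared Core

A few compounds are considered here, and "the series" means these few. Any claim that something is new, unique, unknown or untested is made for them only; others in the source may bear on it.

Compound 1 `O=C(O)Cc1sc(COc2ccc(Cl)cc2)nc1-c1ccc(Cl)cc1`: 50%
Compound 2 `O=C(O)Cc1sc(Cc2ccccc2)nc1-c1ccc(Cl)cc1`: 50%
Compound 3 `Cc1nc(-c2ccc(Cl)cc2)c(CC(=O)O)s1`: 50%

These three compounds were tested in an in vitro functional assay on HEK285-7 cells for antagonist activity at prostaglandin D2 receptor 2 (Homo sapiens), read by BRET and beta-arrestin recruitment; on this read-out lower numbers stand for smaller maximal responses and higher numbers for larger maximal responses. Compound 3 stands level with compounds 1 and 2, as the steps show: no change at the digits printed from compound 1 to compound 2 (within the scatter), no change at the digits printed from compound 1 to compound 3 (within the scatter) and no change at the digits printed from compound 2 to compound 3 (within the scatter). Each of those steps changed the group on the saturated chain carbon bound to an aromatic carbon, and none of them moved the maximal response. Compound 4 `Nc1nc(-c2ccc(Cl)cc2)c(CC(=O)O)s1` differs from compound 3 at another place: amino in place of methyl on an aromatic carbon. Going by the values given here, no measured step touches this ring position, so the earlier steps bear on it only by showing that changes around the shared core left the read-out unmoved. The expectation is therefore no step beyond the scatter, no change at the digits printed from compound 3 to compound 4 (within the scatter). Compound 4 is estimated at 50%, between 35% and 65%.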

Compound 4, largest response reached (reported as efficacy), in percent of the reference or control that the assay uses: 50%
Compound 4: the middle estimate sits on the measured number at the digits printed; low and high end bracket the measured number.
By their numbers in this assay, from the lowest: compounds 1, 2, 3 and 4 (each within the scatter of the next).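

Going by these compounds alone, on the aromatic carbon next to the ring nitrogen and next to the ring sulfur, amino in place of methyl gives no change at the digits printed from compound 3 to compound 4 (within the scatter) in this assay and so is the first measured change at this place. Amino, unlike methyl, counts a hydrogen-bond donor and acceptor, yet that difference leaves the maximal response level, and amino in place of benzyl also gives no change at the digits printed from compound 2 to compound 4 (within the scatter) here. No evidence is available to explain this result. The compounds shown leave open whether dimethylamino, acetylamino or hydroxyl at this place would also stay level.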